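The compounds below may be only part of what the source reports. "The series", "measured", "known", "first", "only" and "open" are said of these compounds alone.

Working notes on the series.

Compound 1 `NC(=O)c1nccn([C@@H]2O[C@H](CO)[C@@H](O)[C@H]2O)c1=O` is the simplest member. In an ADME assay on MDCK cells (Canis lupus familiaris) for cytotoxicity, read by microscopy, with a stated time of 3 days (a higher number here means that more compound is tolerated, a lower number that less compound is tolerated), compound 1 gives only a limit, > 250000 nM, and no number. Compound 2 `CCCCCCCCCCCCCCC(=O)Oc1ccc(COP(=O)(OCc2ccc(OC(=O)CCCC)cc2)OP(=O)(O)OC[C@H]2O[C@@H](n3cc(F)nc(C(N)=O)c3=O)[C@H](O)[C@@H]2O)cc1` carries the diester phosphate arrangement on the same nucleoside and adds a fluoro on the six-membered aromatic ring with 2 nitrogen. In this assay compound 2 gives 21000 nM, the only number shown in the set. Going by the values given here, the one further value shown is the limit of compound 1, as noted (the limit of > 250000 nM in this assay, at which 1 of the 2 values shown sits). Among the compounds with values here, no step between two measured compounds can be stated, since compound 1 and compound 2 differ in more than one place.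

Compound 3 `CCCCCCCCCCCCCCC(=O)Oc1ccc(COP(=O)(OCc2ccc(OC(=O)CCCC)cc2)OP(=O)(O)OC[C@H]2O[C@@H](n3ccnc(C(N)=O)c3=O)[C@H](O)[C@@H]2O)cc1` is the unmeasured member and differs from compound 2 as follows: hydrogen in place of fluoro on an aromatic carbon. For this assay the step from compound 2 to compound 3 is expected to be small, in either direction, and not clearly beyond the scatter; the estimated step is a 1.4-fold higher number from compound 2 to compound 3 (0.15 log units; within the scatter). The expected value for compound 3 in this assay is 30000 nM, with a range from 10000 nM to 100000 nM.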

Compound 3, minimum cytotoxic concentration: 21000 nM
Beside the measured number, compound 3's estimate is 1.4-fold (0.15 log units) above it, within the range that was stated.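

In this assay, hydrogen in place of fluoro on the aromatic carbon next to the ring nitrogen gives no change at the digits printed from compound 2 to compound 3 (within the scatter). Going by these compounds alone, this is the first pair that differs in one place only, so this position can now be read on its own: with the diester phosphate arrangement and the rest of the structure held constant, fluoro and hydrogen cannot be told apart at this carbon in this assay. No information at hand bears on why the two compounds read alike.

It remains open whether another group on this same aromatic carbon, such as an amine, a chlorine or a methyl, would also leave the reading in this assay unmoved, as only fluoro and hydrogen are shown there. Also open is how far the reading follows the ester chains of the diester phosphate arrangement, since no pair shown changes them alone, and a longer chain or a carboxylic acid at the end of those esters would address this directly.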